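Replacing 1H-indol-1-yl with (pyridin-2-yl)oxy: expected effect

The source may report more compounds than this note shows. Statements on the series, on what has been measured and on what is new or still open speak of the compounds shown alone.

In a functional assay on CCRF-CEM cells (Homo sapiens) for inhibition, with a stated time of 72 h (on this read-out higher numbers stand for weaker inhibition and lower numbers for stronger inhibition), two numbers are available so far. Compound 2 (`[N-]=[N+]=NCc1ncnc2c1ncn2[C@@H]1O[C@H](CO)[C@@H](O)[C@H]1O`) gives 390 nM there. For the measured compounds named here, compound 3 (`OC[C@H]1O[C@@H](n2cnc3c(Cn4ccc5ccccc54)ncnc32)[C@H](O)[C@@H]1O`) gives 3400 nM and so holds the higher of the two numbers, with compound 2 as its only measured neighbour. Compound 1 (`OC[C@H]1O[C@@H](n2cnc3c(COc4ccccc4)ncnc32)[C@H](O)[C@@H]1O`) stands as "not determined" (no result reported) and offers no number for comparison.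

The next structure, compound 4 (`OC[C@H]1O[C@@H](n2cnc3c(COc4ccccn4)ncnc32)[C@H](O)[C@@H]1O`), carries (pyridin-2-yl)oxy in place of 1H-indol-1-yl on a saturated chain carbon bound to an aromatic carbon.

Going by the values given here, the one measured step at this place is an 8.7-fold higher number from compound 2 to compound 3 (0.94 log units; beyond the scatter) and it swaps azido for 1H-indol-1-yl. That modest step, beyond the scatter, shows that the number moves with the group held at this place. A single step sets no trend, however, and no number yet exists for a compound with (pyridin-2-yl)oxy. Its size is therefore taken only as a rough outer bound, and no step beyond the scatter is expected, with a slight lean towards a lower number. The estimated change is a 1.7-fold lower number from compound 3 to compound 4 (0.23 log units; within the scatter) in this assay on present evidence. Compound 4 is estimated at 2000 nM with an expected range from 500 nM to 9000 nM until a measurement is available.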

Compound 4, half-maximal inhibitory concentration: 16600 nM
The estimate for compound 4 lay 8.3-fold (0.92 log units) below the measured number; measured number outside the range, above it.
By their numbers in this assay, from the lowest: compound 2; then compound 3; then compound 4.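

In this assay the exchange of 1H-indol-1-yl for (pyridin-2-yl)oxy gives a 4.9-fold higher number from compound 3 to compound 4 (0.69 log units; beyond the scatter) and so shows that the number also moves between two aromatic groups at this place, not only on leaving azido. Set against azido, the same group gives a 43-fold higher number from compound 2 to compound 4 (1.63 log units; beyond the scatter) and this takes the measured range at this place from a modest to a large span, with azido giving the strongest inhibition and (pyridin-2-yl)oxy the weakest of the three. (pyridin-2-yl)oxy has fewer heavy atoms than 1H-indol-1-yl and gives the higher number, so a smaller group does not bring stronger inhibition in this one pair, and nothing at hand bears on the reason for either step.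

Compound 1 has no number, so the compounds shown leave open what the ring nitrogen of (pyridin-2-yl)oxy contributes compared with the plain phenoxy group of compound 1. They also leave open how a basic amine, a carboxylic acid or a longer carbon chain on this saturated chain carbon would compare with azido.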